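Swapping Dimethylsulfamoyl for Propylsulfanyl on the Side Chain

The compounds below may be only part of what the source reports. "The series", "measured", "known", "first", "only" and "open" are said of these compounds alone.

Compound 1 `Cn1c(=N)sc2cc(OC(F)(F)F)ccc21` carries the shared core with a methyl on the aromatic nitrogen. In a functional assay on the whole organism with Rattus norvegicus as the target (on this read-out lower numbers stand for an effect already at smaller amounts and higher numbers for an effect only at larger amounts of compound), compound 1 gives 5 mg/kg. Compound 2 `CN(C)S(=O)(=O)CCn1c(=N)sc2cc(OC(F)(F)F)ccc21` has (dimethylsulfamoyl)methyl in place of hydrogen on a saturated chain carbon bound to an aromatic nitrogen. In this assay compound 2 reaches only a limit, > 10 mg/kg, so its number is not known. On these data alone, the resulting step, an at least 2.0-fold higher number from compound 1 to compound 2 (0.30 log units; that floor lies within the scatter), rests on (the limit of > 10 mg/kg in this assay, at which 1 of the 2 values shown sits), and its true size stays open; compound 2 stands somewhere past that limit.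

Compound 3 `CCCSCCn1c(=N)sc2cc(OC(F)(F)F)ccc21` differs from compound 2 in one place: propylsulfanyl in place of dimethylsulfamoyl on a saturated chain carbon, two bonds along the chain from an aromatic nitrogen. For the measured compounds named here, no measured step covers this change; the only step on this chain is an at least 2.0-fold higher number from compound 1 to compound 2 (0.30 log units; that floor lies within the scatter), which says that adding a group there raised the number without saying how the group's nature matters. With compound 2 known only as a limit, the author expects compound 3 to stay near the limit region, and estimates for compound 3 a value of 10 mg/kg, with a range from 3 mg/kg to 30 mg/kg. The step this estimate means is a number no higher from compound 2 to compound 3 (the limit leaves the size open), though it is expected to remain within the scatter.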

Compound 3, dose for half-maximal effect: 2.4 mg/kg
Compound 3: middle estimate off by 4.2-fold (0.62 log units), on the high side, and the stated range ends above it.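

In this assay, for the compounds shown here, the nature of the group on this side chain clearly matters, which the one earlier step could not show. Propylsulfanyl in place of dimethylsulfamoyl gives an at least 4.1-fold lower number from compound 2 to compound 3 (0.61 log units; beyond the scatter), and that size is only a floor, since compound 2 is known through a limit: the limit of > 10 mg/kg in this assay, at which 1 of the 3 values shown sits. Adding to the chain also does not in itself raise the number, for (propylsulfanyl)methyl in place of hydrogen gives a 2.1-fold lower number from compound 1 to compound 3 (0.32 log units; beyond the scatter), so compound 3 goes against the direction suggested by the earlier step, whose floor lay within the scatter.

On these data alone, how far compound 2 really stands from compound 3 remains open, and so does whether the gain belongs to the sulfur of propylsulfanyl or to its carbon chain, a question that a plain butyl group in the same place could address. Also open, as far as these compounds go, is whether the sulfur must stay as a thioether, or whether a propylsulfonyl group, an ethylsulfanyl group or a longer chain such as pentylsulfanyl would hold the same level.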